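Clearance notes on the amide aryl exchange

This account rests on a few compounds, and the source may have more. Where it says the series, first, only, none or still open, it means among the compounds named here.

Measured so far:
compound 1 `CN1C[C@H](C(=O)Nc2ccc(C(F)(F)F)cc2)[C@@H](c2ccc(/C=C/C(=O)Nc3ccccc3N)cc2)C1` — 6 mL/min/kg
compound 2 `CN1C[C@H](C(=O)Nc2ccc(F)c(Cl)c2)[C@@H](c2ccc(/C=C/C(=O)Nc3ccccc3N)cc2)C1` — 15 mL/min/kg

Two compounds have been run in an in vitro ADME assay on microsomes from liver (Homo sapiens) for pharmacokinetics, read by LC-MS, with a stated time of 10 min, tested at 1 uM; on this read-out higher numbers stand for fast clearance and lower numbers for slow clearance. Compound 1 gives 6 mL/min/kg in this assay, and compound 2 gives 15 mL/min/kg. Among the compounds with values here, the one comparable step is a 2.5-fold higher number from compound 1 to compound 2 (0.40 log units; beyond the scatter), and it places compound 2 at the higher of the two numbers, with compound 1 the nearest and lower.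

Compound 3 `CN1C[C@H](C(=O)Nc2ccc(Cl)cn2)[C@@H](c2ccc(/C=C/C(=O)Nc3ccccc3N)cc2)C1` has not yet been measured. It differs from compound 2 in that (5-chloropyridin-2-yl in place of 3-chloro-4-fluorophenyl on an amide-type nitrogen). Within the data shown here, the single measured step touches the same amide-type nitrogen, but it exchanged substituents on a carbon-only ring rather than the ring itself, so no measured pair covers this exchange directly. What the series does show is that a change at this position can move clearance modestly, as in a 2.5-fold higher number from compound 1 to compound 2 (0.40 log units; beyond the scatter). With nothing pointing firmly in either direction, the step of a 1.3-fold lower number from compound 2 to compound 3 (0.10 log units; within the scatter) is expected to stay within or close to the scatter, and a wide range is allowed for. Compound 3 is therefore estimated at 12 mL/min/kg, expected to lie between 5 mL/min/kg and 30 mL/min/kg.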

Compound 3, clearance: 13 mL/min/kg
For compound 3 the middle estimate is 1.1-fold (0.03 log units) below the measured one, and the stated range covers the measured number.
By their numbers in this assay, from the lowest: compound 1; then compounds 3 and 2 (each within the scatter of the next).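

In this assay, exchanging the carbon-only ring on the amide-type nitrogen for a ring with one hetero atom gives a 1.2-fold lower number from compound 2 to compound 3 (0.06 log units; within the scatter), so this position tolerates a change of the ring itself, and not only of its substituents, with no separation of the two numbers. The second step, a 2.2-fold higher number from compound 1 to compound 3 (0.34 log units; beyond the scatter), places 5-chloropyridin-2-yl on the same side of 4-(trifluoromethyl)phenyl as 3-chloro-4-fluorophenyl, leaving compound 1 apart from both chlorine-bearing compounds among these three. No supporting data are available to explain either the match between compound 2 and compound 3 or the gap to compound 1.

The compounds shown do not separate the ring from its substituent, and a pyridine ring carrying trifluoromethyl in place of chlorine would be needed to tell whether the gap to compound 1 follows the trifluoromethyl group or something else in the exchange. Going by these compounds, it also remains open how clearance responds when the halogens on this ring give way to a very different group, such as a carboxylic acid or a morpholine.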